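The source may hold more compounds than are shown below. What is called first, only, known or untested is meant among the compounds shown, and "the series" means these compounds.

Working notes on the series. Compound 1 `COc1ccc(Cc2cc(-c3ccc(OC)cc3)nn(CC(=O)Nc3ccc(Br)cc3)c2=O)cc1` was run in a functional assay on HL-60 cells (Homo sapiens), read by calcium flux; on this read-out lower numbers stand for an effect already at smaller amounts and higher numbers for an effect only at larger amounts of compound. In this assay compound 1 gives only a limit, > 50000 nM, and no number. Within the data shown here, compound 2 `COc1cccc(Cc2cc(-c3ccc(C)cc3)nn(CC(=O)Nc3ccc(F)cc3)c2=O)c1` differs from compound 1 in more than one place, so no single step between the two can be drawn. In this assay compound 2 also returns only a limit, > 50000 nM. Where compound 1 stands is therefore set by the limit of > 50000 nM in this assay, at which 2 of the 2 values shown sit: no measured compound has produced a numerical half-maximal effective concentration, and compound 1 sits at the same limit as the only other value shown.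

Compound 3 `COc1ccc(Cc2cc(Cc3ccccc3)nn(CC(=O)Nc3ccc(Br)cc3)c2=O)cc1` is the next candidate. Computed from the two structures, the change from compound 1 is benzyl in place of 4-methoxyphenyl on an aromatic carbon of the core. Among the measured compounds shown here, no step between measured compounds is available to calibrate this change, and both values known in this assay are limits. No step beyond the scatter is expected. The step expected in this assay is a step that the limit leaves unreadable from compound 1 to compound 3, a move within scatter. For compound 3 the estimate in this assay is 60000 nM, with an expected range from 20000 nM to 200000 nM, and the assay is expected most likely to report only a limit again.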

Compound 3, half-maximal effective concentration: > 50000 nM
Compound 3: no number, only a limit; the forecaster's own chance of this, stated with the estimate: 80%; the middle value lies beyond the limit too.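

In this assay compound 3 gives > 50000 nM, a limit and not a number. No step can therefore be read between compound 1 and compound 3, as both results are limits: the limit of > 50000 nM in this assay, at which 3 of the 3 values shown sit.

The compounds shown leave open how benzyl compares with 4-methoxyphenyl in this assay, and which structure on the shared core would give a numerical half-maximal effective concentration.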